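The compounds below may be only part of what the source reports. "The series", "measured", "known", "first", "only" and "open" are said of these compounds alone.

Compound 1 `O=C(CSc1nnc(-c2ccncc2)o1)N/N=C/c1ccc(O)cc1` gives 11700 nM in a functional assay on MCF7 cells (Homo sapiens) for cytotoxicity, read by MTT assay, with a stated time of 48 h; on this read-out higher numbers stand for weaker inhibition and lower numbers for stronger inhibition.
Compound 2 `O=C(CSc1nnc(-c2ccncc2)o1)N/N=C/c1ccccc1F` gives 21800 nM in this assay.

The two share one core and differ only in the ring that sits on a carbon with a double bond to nitrogen. Compound 2 holds the higher of the two numbers, but the gap to compound 1 is small: a 1.9-fold higher number from compound 1 to compound 2 (0.27 log units; within the scatter).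

Compound 3 `O=C(CSc1nnc(-c2ccncc2)o1)N/N=C/c1cc(Cl)ccc1O` has not yet been measured. It differs from compound 2 in one place: 5-chloro-2-hydroxyphenyl in place of 2-fluorophenyl on a carbon with a double bond to nitrogen. Among the compounds with values here, the only measured step that bears on this is the exchange of 4-hydroxyphenyl for 2-fluorophenyl, a 1.9-fold higher number from compound 1 to compound 2 (0.27 log units; within the scatter), a shift inside the scatter. Within the data shown here, compound 3 returns a hydroxyl to the ring and adds a chlorine, a pairing no measured compound covers. For compound 3 a step of a 1.6-fold lower number from compound 2 to compound 3 (0.19 log units; within the scatter) is expected, not beyond the scatter. Compound 3 is estimated at 14000 nM, in a range from 4500 nM to 45000 nM.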

Compound 3, half-maximal inhibitory concentration: 5830 nM
Compound 3: the middle estimate sits 2.4-fold (0.38 log units) above what was measured, within the range that was stated.
By their numbers in this assay, from the lowest: compounds 3, 1 and 2 (each within the scatter of the next, the first and the last beyond it).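

In this assay the change from 2-fluorophenyl to 5-chloro-2-hydroxyphenyl brings a 3.7-fold lower number from compound 2 to compound 3 (0.57 log units; beyond the scatter) and so shows that the ring on this carbon can shift the number beyond the scatter, which the earlier step did not show. Set against the 4-hydroxyphenyl ring, the same ring gives a 2.0-fold lower number from compound 1 to compound 3 (0.30 log units; within the scatter) and so these two hydroxyl-bearing rings are not separated in this assay. Nothing measured here gives a reason for the larger step.

The chlorine and the hydroxyl enter together in compound 3, and the compounds shown cannot tell how much of the step belongs to each. Also open, going by these compounds, is how a ring carrying an amine or a carboxylic acid would read at this position, and whether changes elsewhere on the shared core would move the number at all.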